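The source may hold more compounds than are shown below. What is called first, only, known or untested is meant among the compounds shown, and "the series" means these compounds.

Two members of the series have numbers in a physicochemical assay for acid dissociation, so far. Compound 1 `FC(F)(F)c1ccc(-c2ccc3c(NCCCNCc4ccco4)ccnc3c2)cc1` gives 9.47 and stands highest of the two, though its nearest neighbour, compound 2 `COc1cccc(Oc2ccc3c(NCCCNCc4cc(F)ccc4OC)ccnc3c2)c1`, gives 9.28, a gap within the scatter, so no order between them can be read. Compound 3 `CCC(CC)c1ccc2c(NCCCNCc3ccco3)ccnc2c1` has not yet been measured in this assay. It differs from compound 1 by pentan-3-yl in place of 4-(trifluoromethyl)phenyl on an aromatic carbon, a change at an aromatic carbon remote from the amine that carries the proton. Within the data shown here, no step between measured compounds is known, so only a step of a number 0.08 log units higher from compound 1 to compound 3 (within the scatter) is expected, none beyond the scatter. Compound 3 is estimated at 9.55, between 9.2 and 9.9.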

Compound 3, acid dissociation constant: 9.47
Estimate against measurement, compound 3: 0.08 log units above; the measured number falls inside the stated range.
By their numbers in this assay, from the lowest: compounds 2, 1 and 3 (each within the scatter of the next).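

In this assay, among these compounds, the exchange of 4-(trifluoromethyl)phenyl for pentan-3-yl on this aromatic carbon gives no change at the digits printed from compound 1 to compound 3 (within the scatter) and is the first step read at this position. For this one pair, the six-membered aromatic ring and the three fluorine atoms leave this place with no shift beyond the scatter. Nothing on hand accounts for this result. As far as these compounds go, whether a carboxylic acid or an amine on this aromatic carbon would shift the number beyond the scatter stays open. Also open, from the compounds shown here alone, is whether the same exchange gives the same step in another member of the series.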